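The source may hold more compounds than are shown below. What is called first, only, known or untested is meant among the compounds shown, and "the series" means these compounds.

Among the compounds with values here, in an assay on mitochondria from L6 cells (Rattus norvegicus) for activation, with a stated time of 90 min (a lower number here means that less compound is needed, a higher number that more compound is needed for the effect), compound 1, `Oc1nc2nonc2nc1Nc1ccccc1F`, gives 12500 nM, which is the highest of the two numbers measured so far. Within the data shown here, its only measured neighbour is compound 2, `Oc1nc2nonc2nc1Nc1ccccc1Cl`, which gives 6300 nM, so that the step is a 2.0-fold lower number from compound 1 to compound 2 (0.30 log units; within the scatter). Compound 3, `Oc1nc2nonc2nc1Nc1cccc(C(F)(F)F)c1F`, has not yet been measured; it differs from compound 1 by trifluoromethyl in place of hydrogen on an aromatic carbon. Among the measured compounds shown here, the single measured step concerns a different group and lies within the scatter, so no measured step bears directly on the addition of a trifluoromethyl group. On this basis there is no ground to expect a step beyond the scatter in either direction, only wide uncertainty. Compound 3 is therefore expected to give about 9000 nM, in the range 2500 nM to 32000 nM, an expected step of a 1.4-fold lower number from compound 1 to compound 3 (0.14 log units; within the scatter).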

Compound 3, half-maximal effective concentration: 4900 nM
Compound 3: middle estimate off by 1.8-fold (0.26 log units), on the high side; the range from low to high includes it.
By their numbers in this assay, from the lowest: compounds 3, 2 and 1 (each within the scatter of the next, the first and the last beyond it).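

Trifluoromethyl in place of hydrogen, on an aromatic carbon ortho to a fluoro group, brings a 2.6-fold lower number from compound 1 to compound 3 (0.41 log units; beyond the scatter) in this assay. This is the first listed change to pass beyond the scatter, though only modestly, whereas chloro in place of fluoro gave a 2.0-fold lower number from compound 1 to compound 2 (0.30 log units; within the scatter). So this ring carbon can carry a group of 4 heavy atoms instead of hydrogen without losing activity in this assay, and less compound is needed, but nothing measured here explains the drop.

As far as these compounds go, it remains open whether a methyl group, a chloro atom or a methoxy group on the same carbon would lower the number as far, or whether an amine there would raise it. From the compounds shown here alone, it is also open whether trifluoromethyl would give a similar step on compound 2, which carries chloro instead of fluoro.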